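Notes on aromatic substitution in the series

The source may hold more compounds than are shown below. What is called first, only, known or untested is meant among the compounds shown, and "the series" means these compounds.

Measured so far:
compound 1, `CC1=C(/C=C/C(=O)/C=C/c2ccccc2)C(C)(C)CCC1O`, 15500 nM
compound 2, `CC1=C(/C=C/C(=O)/C=C/c2cccc(C(F)(F)F)c2)C(C)(C)CCC1O`, 3500 nM
compound 3, `CC1=C(/C=C/C(=O)/C=C/c2cccc(F)c2)C(C)(C)CCC1O`, 16000 nM

Compound 1 is the unsubstituted parent. In a functional assay on PC-3 cells (Homo sapiens) for cytotoxicity, read by MTT assay, with a stated time of 72 h (a lower number here means a stronger inhibitor, a higher number a weaker inhibitor), compound 1 gives 15500 nM, the second highest of the three numbers; compound 3 sits within the scatter of it, while compound 2 lies well below.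

Compound 4, `CC1=C(/C=C/C(=O)/C=C/c2ccc([N+](=O)[O-])cc2)C(C)(C)CCC1O`, is the next member and is not yet measured. It differs from compound 1 in one place: nitro in place of hydrogen on an aromatic carbon.

Going by the values given here, two measured steps bear on this change, both substitutions on an aromatic carbon of the same ring, though neither at the same position nor with the same group. The step of a 4.4-fold lower number from compound 1 to compound 2 (0.65 log units; beyond the scatter) lowered the number modestly; the step of a 1.0-fold higher number from compound 1 to compound 3 (0.01 log units; within the scatter) left it unchanged. Taken together they show that a single group on this ring can move the number downward by a modest amount or not at all; no step has raised it. For compound 4 the expectation is therefore a small to modest decrease in this assay, or none beyond the scatter, with no reason from these data to expect an increase.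

Compound 4 is estimated at 8000 nM, with a range of 3000 nM to 22000 nM, corresponding to an expected step of a 1.9-fold lower number from compound 1 to compound 4 (0.29 log units; within the scatter).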

Compound 4, half-maximal inhibitory concentration: 15000 nM
For compound 4 the middle estimate is 1.9-fold (0.27 log units) below the measured one, and the stated range covers the measured number.
By their numbers in this assay, from the lowest: compound 2; then compounds 4, 1 and 3 (each within the scatter of the next).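

In this assay, nitro on the aromatic carbon para to a large group gives a 1.0-fold lower number from compound 1 to compound 4 (0.01 log units; within the scatter), so a substituent at this position, with three heavy atoms in place of a hydrogen, can leave the number where the unsubstituted parent has it. Set beside the earlier steps, a 4.4-fold lower number from compound 1 to compound 2 (0.65 log units; beyond the scatter) and a 1.0-fold higher number from compound 1 to compound 3 (0.01 log units; within the scatter), this leaves trifluoromethyl in compound 2 as the only group on this ring that moves the number beyond the scatter, while compound 3 and compound 4 go against any reading that substitution on this ring lowers the number in general. No available measurement accounts for the absence of a shift with nitro.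

The compounds shown carry their three groups at different positions or with different identities, so they do not separate the effect of the group from that of its place on the ring. An amine or a carboxylic acid on this same aromatic carbon, or trifluoromethyl placed there, would show whether any group at this position moves the number.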